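A chloro to isopropyl swap: what compound 3 might show

The source may report more compounds than this note shows. Statements on the series, on what has been measured and on what is new or still open speak of the compounds shown alone.

Within the data shown here, compound 2 `COc1c(-c2ccccc2Cl)cc(S(=O)(=O)Nc2ccc(F)c(CC(=O)O)c2)c2ccccc12` gives 48.8 mL/min in an ADME assay on microsomes from liver (Mus musculus) for metabolic stability, read by LC-MS, using NADPH, with stated times of 10 min and 60 min, tested at 0.1 uM (a lower number here means slower removal, a higher number faster removal of the compound), the higher of the two numbers measured so far; its nearest neighbour, compound 1 `COc1c(-c2ccc(F)cc2C)cc(S(=O)(=O)Nc2ccc(F)c(CC(=O)O)c2)c2ccccc12`, gives 23.8 mL/min. Among the measured compounds shown here, the only measured step, a 2.1-fold higher number from compound 1 to compound 2 (0.31 log units; beyond the scatter), exchanged the whole aryl group and so bears only loosely on the present change. Compound 3 `COc1c(-c2ccccc2C(C)C)cc(S(=O)(=O)Nc2ccc(F)c(CC(=O)O)c2)c2ccccc12` differs from compound 2 by isopropyl in place of chloro on an aromatic carbon. With a single modest step as guide, the analyst expects a small rise or none beyond the scatter. Compound 3 is thus estimated at 60 mL/min, between 30 mL/min and 120 mL/min, an expected step of a 1.2-fold higher number from compound 2 to compound 3 (0.09 log units; within the scatter).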

Compound 3, intrinsic clearance in a liver preparation (reported as CLH), per the amount of preparation that the assay uses: 139 mL/min
Compound 3: middle estimate off by 2.3-fold (0.36 log units), on the low side; the whole stated range lies below it.
By their numbers in this assay, from the lowest: compound 1; then compound 2; then compound 3.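

Among these compounds, with only the one substituent exchanged at this place, ortho to a large group, this assay shows a 2.8-fold higher number from compound 2 to compound 3 (0.45 log units; beyond the scatter) and so the chloro-to-isopropyl change alone moves the number beyond the scatter, which the earlier whole-aryl exchange could not show. Exchanging the whole aryl group for 2-isopropylphenyl gives a 5.8-fold higher number from compound 1 to compound 3 (0.77 log units; beyond the scatter) and leaves compound 3 with the highest number of the three. Nothing measured here accounts for this rise.

The compounds shown leave open whether a lone methyl or methoxy at this place would fall nearer chloro or isopropyl. Going by these compounds, whether an amine or a hydroxyl there would lower the number also remains open.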